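Methyl for methoxy on the shared core of compound 1

The source may report more compounds than this note shows. Statements on the series, on what has been measured and on what is new or still open speak of the compounds shown alone.

Measured so far in a functional assay on A549 cells (Homo sapiens), read by MTT assay, with a stated time of 72 h; on this read-out higher numbers stand for weaker inhibition and lower numbers for stronger inhibition:
- compound 1, `COc1ncnc2c1c(-c1ccsc1)cn2[C@@H]1O[C@H](CO)[C@@H](O)[C@H]1O`: 5170 nM
- compound 2, `COc1ncnc2c1c(-c1ccoc1)cn2[C@@H]1O[C@H](CO)[C@@H](O)[C@H]1O`: 1160 nM
- compound 3, `COc1ncnc2c1c(-c1ccccc1)cn2[C@@H]1O[C@H](CO)[C@@H](O)[C@H]1O`: a limit, > 20000 nM

Compound 1 holds the highest of the two numbers actually reported in this assay; compound 2 sits nearest, the step being a 4.5-fold lower number from compound 1 to compound 2 (0.65 log units; beyond the scatter). For compound 3 this assay returns only a limit, > 20000 nM, as noted in the limit of > 20000 nM in this assay, at which 1 of the 3 values shown sits. The steps from compound 1 to compound 3 and from compound 2 to compound 3 are therefore also limits, an at least 3.8-fold higher number from compound 1 to compound 3 (0.58 log units; beyond the scatter) and an at least 17-fold higher number from compound 2 to compound 3 (1.23 log units; beyond the scatter).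

Compound 4, `Cc1ncnc2c1c(-c1ccsc1)cn2[C@@H]1O[C@H](CO)[C@@H](O)[C@H]1O`, differs from compound 1 by methyl in place of methoxy on an aromatic carbon. Every measured step changes the aryl group on the five-membered ring instead, so none of them bears on this change, and the data give no direction for it. Compound 4 is therefore expected to stay close to compound 1, with a step of about a 1.0-fold lower number from compound 1 to compound 4 (0.01 log units; within the scatter), not beyond the scatter. The estimate for compound 4 in this assay is 5000 nM, within 1500 nM to 16000 nM.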

Compound 4, half-maximal inhibitory concentration: > 20000 nM
Compound 4: no number, only a limit; the forecaster's own chance of this, stated with the estimate: 12%; middle value at least 4.0-fold (0.60 log units) from the limit.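

In this assay, going by these compounds alone, methyl in place of methoxy on the aromatic carbon next to the ring nitrogen gives an at least 3.8-fold higher number from compound 1 to compound 4 (0.58 log units; beyond the scatter), so this position is not indifferent to the change, although the earlier steps, all at the aryl group, could not show this. Compound 4 gives > 20000 nM, which is a limit and not a number, so the step has a floor but no measured size: the limit of > 20000 nM in this assay, at which 2 of the 4 values shown sit. Both compounds with a number carry methoxy, yet compound 3 carries it too and gives only a limit, so methoxy alone does not secure a measurable value.

As far as these compounds go, whether an amine, an ethoxy group or a chlorine atom at this position would give a measurable value remains open. Also open, from the compounds shown here alone, is whether methyl in place of methoxy has the same outcome alongside the furan-3-yl group of compound 2.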